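The source may report more compounds than this note shows. Statements on the series, on what has been measured and on what is new or still open speak of the compounds shown alone.

Compound 1 `Cc1cccc(NC(=O)c2cccc(/C=C3\CC(=O)N(c4ccccc4)C3=O)c2)c1`: in an ADME assay on HCT-116 cells (Homo sapiens) for cytotoxicity, read by MTT assay, with a stated time of 72 h (on this read-out lower numbers stand for stronger inhibition and higher numbers for weaker inhibition), the result is only a limit of the assay, > 100000 nM.
Compound 2 `COc1ccc(NC(=O)c2cccc(/C=C3\CC(=O)N(c4ccccc4)C3=O)c2)c(C)c1`: in this assay the result is only a limit, > 100000 nM.
Compound 3 `O=C(Nc1cccc(F)c1)c1cccc(/C=C2\CC(=O)N(c3ccccc3)C2=O)c1`: in this assay the result is only a limit, > 100000 nM.

Compound 3 therefore stands where every value shown sits, namely (the limit of > 100000 nM in this assay, at which 3 of the 3 values shown sit). For the measured compounds named here, none of the measured steps can be read: a step that the two limits leave unreadable from compound 1 to compound 2, a step that the two limits leave unreadable from compound 1 to compound 3 and a step that the two limits leave unreadable from compound 2 to compound 3 all run between two limits. Compound 4 `O=C(c1cccc(/C=C2\CC(=O)N(c3ccccc3)C2=O)c1)N1CCCC1` differs from compound 3 by pyrrolidin-1-yl in place of (3-fluorophenyl)amino on a carbonyl carbon. Since the three measured changes on this part of the shared core left the read-out at its limit, no step beyond the scatter is expected for a step that the limit leaves unreadable from compound 3 to compound 4. Compound 4 is estimated at 150000 nM, with a range from 30000 nM to 1000000 nM, most likely again only a limit.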

Compound 4, half-maximal inhibitory concentration: > 100000 nM
Compound 4: only a limit was reported (the forecaster's own chance of this, stated with the estimate: 85%); the middle value does not contradict the limit.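

No step to compound 4 can be read from compound 1, compound 2 or compound 3, because each of the four results is only a limit: the limit of > 100000 nM in this assay, at which 4 of the 4 values shown sit.

The compounds shown leave open which change to the shared core, if any, gives a measurable value in this assay.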